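Trifluoromethyl to methoxy in a small amide series

The compounds below may be only part of what the source reports. "The series", "measured", "known", "first", "only" and "open" are said of these compounds alone.

Measured so far in a functional assay on HL-60 cells (Homo sapiens) for cytotoxicity, read by luminescence and CellTiter-Glo, with a stated time of 3 days; on this read-out lower numbers stand for stronger inhibition and higher numbers for weaker inhibition:
- compound 1 `N#Cc1ccc(NC(=O)c2ccc(Cl)cc2O)cc1` gives 1300 nM
- compound 2 `Cc1ccc(C(=O)Nc2ccc(C#N)cc2)c(O)c1` gives 2420 nM
- compound 3 `N#Cc1ccc(NC(=O)c2ccc(C(F)(F)F)cc2O)cc1` gives 1030 nM

Compound 3 stands at the low end of these numbers, together with compound 1 rather than ahead of it. The gap there is small (a 1.3-fold lower number from compound 1 to compound 3 (0.10 log units; within the scatter)), and the only separation beyond the scatter is modest (a 2.3-fold lower number from compound 2 to compound 3 (0.37 log units; beyond the scatter)).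

Compound 4 `COc1ccc(C(=O)Nc2ccc(C#N)cc2)c(O)c1` has methoxy in place of trifluoromethyl on an aromatic carbon, meta to a hydroxy group and para to a large group (methoxy in place of trifluoromethyl on an aromatic carbon). Among the compounds with values here, no measured compound carries methoxy, so the measured steps bear on this change only indirectly. Exchanging trifluoromethyl for methyl gave the modest step above, while exchanging chloro for methyl stayed within the scatter (a 1.9-fold higher number from compound 1 to compound 2 (0.27 log units; within the scatter)). A modest move towards a higher number is therefore expected in this assay rather than a large one. The expected step is a 1.9-fold higher number from compound 3 to compound 4 (0.29 log units; within the scatter) as an estimate. Compound 4 is estimated at 2000 nM with an expected range from 900 nM to 4500 nM for its measurement.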

Compound 4, half-maximal inhibitory concentration: 5470 nM
The estimate for compound 4 lay 2.7-fold (0.44 log units) below the measured number, outside the stated range (above it).
By their numbers in this assay, from the lowest: compounds 3, 1 and 2 (each within the scatter of the next, the first and the last beyond it); then compound 4.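

In this assay, methoxy on this aromatic carbon stands apart from all three groups seen earlier: the number rises against trifluoromethyl (a 5.3-fold higher number from compound 3 to compound 4 (0.73 log units; beyond the scatter)), against chloro (a 4.2-fold higher number from compound 1 to compound 4 (0.62 log units; beyond the scatter)) and against methyl (a 2.3-fold higher number from compound 2 to compound 4 (0.35 log units; beyond the scatter)), each step beyond the scatter. Chloro, methyl and trifluoromethyl had spanned only a narrow range, so this position turns out to respond more strongly to the choice of group than those three compounds could show. Nothing available here explains why methoxy differs from the other three groups.

The compounds shown leave open whether the higher number is particular to methoxy or would also appear with an ethoxy group, an amine or a carboxylic acid on the same carbon. They also leave open whether the same order of groups would hold if the hydroxy group of the shared core were replaced by a fluorine atom.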